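The source may report more compounds than this note shows. Statements on the series, on what has been measured and on what is new or still open speak of the compounds shown alone.

Compound 1, `CCOC(=O)/C=C/c1ccncc1-c1ccc2[nH]ccc2c1`, gives in a functional assay on MCF7 cells (Homo sapiens) for inhibition, read by sulforhodamine B assay, with a stated time of 72 h (a lower number here means a stronger inhibitor of growth, a higher number a weaker inhibitor of growth), a value of > 10000 nM, which is a limit of the assay and not a number.
Compound 2, `CCOC(=O)/C=C/c1ccncc1-c1ccc2c(ccn2C)c1`, gives in this assay a value of 8670 nM.
Compound 3, `CNC(=O)CCc1ccncc1-c1ccc2ccccc2c1`, gives in this assay a value of > 10000 nM, again a limit and not a number.

Compound 3 thus stands at the limit of > 10000 nM in this assay, at which 2 of the 3 values shown sit, so no number for it is known, only that it is a weak inhibitor of growth at best. Compound 4, `O=C(/C=C/c1ccncc1-c1ccc2ccccc2c1)NC1CC1`, differs from compound 3 in one place: 2-(cyclopropylcarbamoyl)ethenyl in place of 2-(methylcarbamoyl)ethyl on an aromatic carbon. Going by the values given here, the only measured step, an at least 1.1-fold lower number from compound 1 to compound 2 (0.06 log units; that floor lies within the scatter), concerns a different change on a different part of the shared core and so does not bear on this one; it also lies within the scatter. Among the compounds with values here, no measured step therefore speaks to the step from compound 3 to compound 4, and the two values for compounds 1 and 3 sit at the limit while compound 2 sits close to it. On this thin basis compound 4 is expected to stay near the limit, with an estimated step of an at least 1.1-fold lower number from compound 3 to compound 4 (0.04 log units; that floor lies within the scatter). The estimate for compound 4 is 9000 nM, in a range from 2500 nM to 30000 nM.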

Compound 4, concentration for 50% growth inhibition: 6840 nM
For compound 4 the middle estimate is 1.3-fold (0.12 log units) above the measured one; the range from low to high includes it.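

In this assay the change on the aromatic carbon opposite the ring nitrogen gives an at least 1.4-fold lower number from compound 3 to compound 4 (0.16 log units; that floor lies within the scatter). On these data alone, that figure is only a floor, and the true size of the step stays unknown because compound 3 gives a limit and not a number: the limit of > 10000 nM in this assay, at which 2 of the 4 values shown sit. What is new is that compound 4 gives a readable number, 6840 nM, so a group carrying a three-membered ring and an extra double bond at this position still allows a measurable, if weak, inhibition of growth.

The change swaps two things at once, ethyl for ethenyl in the chain and methyl for cyclopropyl on the amide, so the compounds shown do not tell which of the two counts. Also open, as far as these compounds go, is how an amine, a carboxylic acid or a longer chain at this position would read in this assay.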